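A few compounds are considered here, and "the series" means these few. Any claim that something is new, unique, unknown or untested is made for them only; others in the source may bear on it.

Measured in a functional assay on the whole organism with Mus musculus as the target, with a stated time of 90 min, at a dose of 25 umol/kg by the oral route; a lower number here means a weaker effect, a higher number a stronger effect of the compound at the dose given:
compound 1 `C[C@H](NC(=O)CN(c1nc(Cl)nc2c1ncn2C1CCCCO1)C1CC1)C(=O)OCc1ccccc1` gives 32.1%
compound 2 `N=C(N)NCCC[C@H](NC(=O)CN(c1nc(Cl)nc2c1ncn2C1CCCCO1)C1CC1)C(=O)OCc1ccccc1` gives 61.6%
compound 3 `O=C(CN(c1nc(Cl)nc2c1ncn2C1CCCCO1)C1CC1)N[C@@H](CCC(=O)OCc1ccccc1)C(=O)OCc1ccccc1` gives 25.2%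

Compound 3 has the lowest of the three numbers in this assay; it lies within the scatter of compound 1, while the gap to compound 2 is large, as a number 36.4 percentage points lower from compound 2 to compound 3 (beyond the scatter) shows. Compound 4 `C[C@@H](O)[C@H](NC(=O)CN(c1nc(Cl)nc2c1ncn2C1CCCCO1)C1CC1)C(=O)OCc1ccccc1` is not yet measured. The change is 1-hydroxyethyl in place of 2-(benzyloxycarbonyl)ethyl on a saturated chain carbon bound to an amide-type nitrogen and a carbonyl carbon. Of the measured steps, a number 6.9 percentage points lower from compound 1 to compound 3 (within the scatter) bears most directly: adding the benzyl ester side chain to the methyl of compound 1 moved nothing beyond the scatter, so taking it away again should return to about the level of compound 1. Nothing measured covers the hydroxyl of 1-hydroxyethyl, and a number 29.5 percentage points higher from compound 1 to compound 2 (beyond the scatter) concerns an unrelated group. A step within the scatter is therefore expected, a number 7.8 percentage points higher from compound 3 to compound 4 (within the scatter). Compound 4 is estimated at 33%, between 18% and 50%.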

Compound 4, a percentage reported as activity, at one dose (the size of the read-out at that dose, not a potency): 23.4%
Estimate against measurement, compound 4: 9.6 percentage points above; low and high end bracket the measured number.
By their numbers in this assay, from the lowest: compounds 4, 3 and 1 (each within the scatter of the next); then compound 2.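

With 1-hydroxyethyl on the saturated chain carbon bound to an amide-type nitrogen and a carbonyl carbon, compound 4 stays level with both compound 1 (a number 8.7 percentage points lower from compound 1 to compound 4 (within the scatter)) and compound 3 (a number 1.8 percentage points lower from compound 3 to compound 4 (within the scatter)), so a small hydroxyl-bearing group and the much larger 2-(benzyloxycarbonyl)ethyl read alike here. Only the group in compound 2 stands apart (a number 38.2 percentage points lower from compound 2 to compound 4 (beyond the scatter)). No supporting data bear on why. 
Open, going by these compounds, is whether a simple amine or a carboxylic acid on a shorter or longer chain at this carbon would approach compound 2, and whether ethyl would read the same as 1-hydroxyethyl.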